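This account rests on a few compounds, and the source may have more. Where it says the series, first, only, none or still open, it means among the compounds named here.

Working notes on the hydroxamic acid series. In an assay on isolated protein for inhibition of protein deacetylase HDAC6 (Homo sapiens), with a stated time of 15 min, tested at 1 uM (on this read-out lower numbers stand for less inhibition and higher numbers for more inhibition at the one concentration tested (going by the name of the read-out)), compound 1 `Nc1ncnc2c1c(-c1cnc3[nH]ccc3c1)nn2CCCCCCCCC(=O)NO` gives 99.2%. Compound 2 `Nc1nc2cc(-c3nn(CCCCCCCCCC(=O)NO)c4ncnc(N)c34)ccc2o1` gives 98.2% in this assay. Of the two numbers recorded, compound 1 holds the top one, but the gap to compound 2 lies within the scatter, so the two compounds cannot be told apart on this read-out. Both carry a long saturated chain ending in the hydroxamic acid and both give a high number on this read-out at the single concentration tested, the two numbers being level with each other.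

Compound 3 `Nc1ncnc2c1c(-c1cnc3[nH]ccc3c1)nn2CCCCCCC(=O)NO` has not yet been measured in this assay. It differs from compound 1 by hydroxycarbamoyl in place of 2-(hydroxycarbamoyl)ethyl on a saturated chain carbon, six bonds along the chain from an aromatic nitrogen. For the measured compounds named here, no step between two measured compounds covers such a change, so the size of the shift is not known from the numbers in hand. Because compound 1 gives 99.2% and there is little room above it, the expected step of a number 9.2 percentage points lower from compound 1 to compound 3 (within the scatter) is a small one downward or none beyond the scatter. Compound 3 is therefore expected to give about 90%, with a range from 60% to 99%.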

Compound 3, a percentage reported as inhibition, at one concentration (the size of the read-out at that concentration, not a potency): 99.1%
Estimate against measurement, compound 3: 9.1 percentage points below; measured number above the stated range.
By their numbers in this assay, from the lowest: compounds 2, 3 and 1 (each within the scatter of the next).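

Replacing 2-(hydroxycarbamoyl)ethyl with hydroxycarbamoyl on a saturated chain carbon, six bonds along the chain from an aromatic nitrogen, gives a number 0.1 percentage points lower from compound 1 to compound 3 (within the scatter) in this assay. For the compounds shown here, this is the first direct comparison in which only the chain changes, and it shows that, at the single concentration tested, this read-out does not separate the two chain lengths on the core of compound 1. Nothing at hand bears on why the number holds across this change.

With both numbers close to the top of the percentage scale, a read-out at one concentration leaves open whether the two chain lengths differ in potency. Also open, on these data alone, is whether a still shorter chain, or a carboxylic acid in place of the hydroxycarbamoyl end, would keep the number at this level.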